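The compounds below may be only part of what the source reports. "The series", "measured", "known", "first", "only" and "open" are said of these compounds alone.

Compound 1 `COC(=O)[C@@]1(C)CCC=C2[C@@H]1CC[C@@H](C)[C@]2(C)Cc1c[nH]c2c(C)cccc12`: 11000 nM
Compound 2 `COC(=O)[C@@]1(C)CCC=C2[C@@H]1CC[C@@H](C)[C@]2(C)Cc1c[nH]c2c(Br)cccc12`: 22000 nM
Compound 3 `COC(=O)[C@@]1(C)CC[C@@H]2C3=C1CC[C@@H](C)[C@]3(C)C[C@@H]1c3cc(C)ccc3N[C@H]21`: 27000 nM

All three were tested in a functional assay on A549 cells (Homo sapiens) for inhibition, read by sulforhodamine B assay, with a stated time of 48 h; on this read-out higher numbers stand for weaker inhibition of growth and lower numbers for stronger inhibition of growth. Compound 1 and compound 2 share a core and differ in one place, (bromo in place of methyl on an aromatic carbon), and this change gave a 2.0-fold higher number from compound 1 to compound 2 (0.30 log units; within the scatter). Compound 3 has the same atoms as compound 1 joined differently; the difference between the two cores is not broken down here.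

Compound 4 `COC(=O)[C@@]1(C)CC[C@@H]2C3=C1CC[C@@H](C)[C@]3(C)C[C@@H]1c3cc(Br)ccc3N[C@H]21` has not yet been measured. It stands to compound 3 as compound 2 stands to compound 1: bromo in place of methyl on an aromatic carbon. The two changes are the same kind of change rather than the same. The surroundings differ: in compound 1 the carbon belongs to a fused or bridged system of two rings, ortho to a fused ring and meta to a fused ring, whereas in compound 3 it belongs to a system of five rings, meta to a fused ring and para to a fused ring.

The expectation rests on compound 1 and compound 2, where a 2.0-fold higher number from compound 1 to compound 2 (0.30 log units; within the scatter) stayed within the scatter. The step from compound 3 to compound 4 in this assay is therefore expected to be modest, about a 1.5-fold higher number from compound 3 to compound 4 (0.17 log units; within the scatter). Compound 4 is estimated at 40000 nM, most likely between 15000 nM and 110000 nM.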

Compound 4, concentration for 50% growth inhibition: 40000 nM
For compound 4 middle estimate and measured number coincide at the digits printed, within the range that was stated.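

In this assay, putting bromo in place of methyl on the core of compound 3 gave a 1.5-fold higher number from compound 3 to compound 4 (0.17 log units; within the scatter), and this step can be set beside the same change on the core of compound 1: the same change on two cores in this assay, a 2.0-fold higher number (0.30 log units; within the scatter) from compound 1 to compound 2 and a 1.5-fold higher number (0.17 log units; within the scatter) from compound 3 to compound 4, 1.4-fold (0.13 log units) apart, within the scatter of two such steps So the swap behaved alike on both cores, even though the aromatic carbon carrying it sits in different surroundings in each. This does not show that bromo and methyl truly differ in this assay, since each step on its own lies within the scatter, and two pairs are too few to give a rule for other cores in the series.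

The compounds shown leave open whether a different group on that aromatic carbon, such as an amine, a methoxy group or a carboxylic acid, would shift the number beyond the scatter. They also leave open whether changing another part of the molecule, such as replacing the methyl ester with an amide, would do so.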